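Swapping the aryl group on an acrylamide side chain

A few compounds are considered here, and "the series" means these few. Any claim that something is new, unique, unknown or untested is made for them only; others in the source may bear on it.

Three compounds share a common core and differ in the acyl group on the amide nitrogen. Compound 1 `COc1cccc(C(=O)Nc2cc(Sc3ncn[nH]3)c(O)c3ccccc23)c1` carries a 3-methoxyphenyl on the carbonyl carbon and in a functional assay on PC-3 cells (Homo sapiens) for antiproliferative activity, read by MTT assay, with a stated time of 48 h (a lower number here means a stronger inhibitor, a higher number a weaker inhibitor), compound 1 gives 42100 nM. Compound 3 `O=C(Nc1cc(Sc2ncn[nH]2)c(O)c2ccccc12)c1ccc(Cl)cc1` carries a 4-chlorophenyl instead, and compound 3 gives 5520 nM; the change gives a 7.6-fold lower number from compound 1 to compound 3 (0.88 log units; beyond the scatter). Compound 2 `O=C(/C=C/c1ccc([N+](=O)[O-])cc1)Nc1cc(Sc2ncn[nH]2)c(O)c2ccccc12` extends the acyl group into a double-bonded chain ending in a 4-nitrophenyl, and for compound 2 the assay reports only a limit, > 100000 nM; this is the limit of > 100000 nM in this assay, at which 1 of the 3 values shown sits, so compound 2 stands at the weak end of the three values shown.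

Compound 4 `COc1ccc(/C=C/C(=O)Nc2cc(Sc3ncn[nH]3)c(O)c3ccccc23)cc1OC` is not yet measured. It differs from compound 2 by 3,4-dimethoxyphenyl in place of 4-nitrophenyl on a double-bonded chain carbon bound to a double-bonded chain carbon. Among the measured compounds shown here, the only measured step that bears on it, the aryl swap from compound 1 to compound 3, was modest, and it sits on a carbonyl carbon rather than on the chain. Since compound 2 offers only a limit, the direction is uncertain, and compound 4 is expected to remain weak. The expected step is an at least 1.4-fold lower number from compound 2 to compound 4 (0.15 log units; that floor lies within the scatter), and for compound 4 the estimate is 70000 nM, within a range from 15000 nM to 300000 nM.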

Compound 4, half-maximal inhibitory concentration: > 100000 nM
Compound 4: no number, only a limit; the forecaster's own chance of this, stated with the estimate: 45%; middle value at least 1.4-fold (0.15 log units) away from the limit.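

In this assay compound 2 and compound 4 both return only a limit, so no step can be read between them: the limit of > 100000 nM in this assay, at which 2 of the 4 values shown sit. The compounds shown leave open whether 3,4-dimethoxyphenyl and 4-nitrophenyl on the double-bonded chain differ at all in this assay.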